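This account rests on a few compounds, and the source may have more. Where it says the series, first, only, none or still open, it means among the compounds named here.

Working notes on the series. Going by the values given here, in a functional assay on T47D cells (Homo sapiens) for inhibition, read by sulforhodamine B assay, with a stated time of 48 h (on this read-out higher numbers stand for weaker inhibition of growth and lower numbers for stronger inhibition of growth), compound 1 `COc1cc(-c2nn(-c3cccc(NC(=O)c4cccc(C(F)(F)F)c4)c3)cc2-c2ccncc2)ccc1Cl` gives 2550 nM, the highest of the two numbers so far; its nearest neighbour is compound 2 `O=C(Nc1cccc(-n2cc(-c3ccncc3)c(-c3ccc(Cl)c(O)c3)n2)c1)Nc1cc(C(F)(F)F)cc(C(F)(F)F)c1`, which in this assay gives 1820 nM, a gap that lies within the scatter, so the two cannot be ordered. Among the compounds with values here, compound 2 differs from compound 1 in more than one place, and no single step between them is set out.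

Compound 3 `COc1cc(-c2nn(-c3cccc(NC(=O)Nc4ccc(Cl)c(C(F)(F)F)c4)c3)cc2-c2ccncc2)ccc1Cl` is the unmeasured analogue of compound 1. The change is (4-chloro-3-(trifluoromethyl)phenyl)amino in place of 3-(trifluoromethyl)phenyl on a carbonyl carbon; the carbonyl carbon thus carries two amide-type nitrogens in compound 3. With no measured step of this kind in the set, the expectation rests on compound 2, whose value of 1820 nM shows that a urea of this shape sits in the same range as compound 1. The step from compound 1 to compound 3 is therefore expected to be a 1.7-fold lower number from compound 1 to compound 3 (0.23 log units; within the scatter), a small move toward stronger inhibition of growth that may not clear the scatter. Compound 3 is expected to give about 1500 nM in this assay, with a range from 500 nM to 4500 nM.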

Compound 3, concentration for 50% growth inhibition: 1230 nM
The estimate for compound 3 lay 1.2-fold (0.09 log units) above the measured number; the measured number falls inside the stated range.
By their numbers in this assay, from the lowest: compounds 3, 2 and 1 (each within the scatter of the next, the first and the last beyond it).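

In this assay, going by these compounds alone, (4-chloro-3-(trifluoromethyl)phenyl)amino in place of 3-(trifluoromethyl)phenyl on a carbonyl carbon gives a 2.1-fold lower number from compound 1 to compound 3 (0.32 log units; beyond the scatter), a modest move toward stronger inhibition of growth and the first single-place step. It shows that the number responds to a change at this position, although the step is small and the entering group adds both an amide-type nitrogen and a chlorine, so it cannot be divided between them. No measurement shown here accounts for the step.

From the compounds shown here alone, whether the nitrogen, the chlorine or both carry the step remains open; 3-(trifluoromethyl)phenylamino on the same carbonyl carbon would separate them. Also open, going by these compounds, is how this position responds to a piperidine or a carboxylic acid in place of the (4-chloro-3-(trifluoromethyl)phenyl)amino group.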